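Notes on the step from compound 3 to compound 4

The source may hold more compounds than are shown below. What is called first, only, known or untested is meant among the compounds shown, and "the series" means these compounds.

Measured compounds in a functional assay on A549 cells (Homo sapiens) for inhibition, read by XTT assay, with a stated time of 48 h; a higher number here means a weaker inhibitor, a lower number a stronger inhibitor:
- compound 1 `COc1ccc(C(=O)/C(=C/c2ccccc2F)COC(C)=O)cc1` gives 22500 nM
- compound 2 `CCC(/C=C(\COC(=O)c1ccccc1)C(=O)c1ccc(OC)cc1)CC` gives a limit of the assay, > 100000 nM
- compound 3 `COc1ccc(C(=O)/C(=C/c2ccccc2F)CCOC(C)=O)cc1` gives a limit of the assay, > 100000 nM

Compound 3 stands at the weak end of what has been measured: its result in this assay is a limit and not a number, so its true position is not known beyond that. Among the compounds with values here, the one measured step, an at least 4.4-fold higher number from compound 1 to compound 3 (0.64 log units; beyond the scatter), led into that limit.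

Compound 4 `CCC(/C=C(\CCOC(C)=O)C(=O)c1ccc(OC)cc1)CC` differs from compound 3 in one place: pentan-3-yl in place of 2-fluorophenyl on a double-bonded chain carbon bound to a double-bonded chain carbon. Within the data shown here, no measured step covers this exchange. Among the measured compounds shown here, the only measured step, an at least 4.4-fold higher number from compound 1 to compound 3 (0.64 log units; beyond the scatter), concerns the chain and not this position, so it says nothing directly about compound 4. Compound 2 also carries a pentan-3-yl group and sits at the limit of > 100000 nM in this assay, at which 2 of the 3 values shown sit. Compound 3 is already there. No shown value suggests that this exchange would lift a compound out of the limit, and the expectation is therefore that compound 4 remains at or beyond it; the step that the limit leaves unreadable from compound 3 to compound 4 is expected to be nothing beyond the scatter. The estimate for compound 4 in this assay is 200000 nM, within 60000 nM to 800000 nM.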

Compound 4, half-maximal inhibitory concentration: > 100000 nM
Compound 4 was reported as a limit; the forecaster's own chance of this, stated with the estimate: 85%; the middle value lies beyond the limit too.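

In this assay compound 4 gives > 100000 nM, a limit of the assay and not a number. The steps to compound 4 from compound 3 and from compound 2 cannot be read, as all three compounds sit at the same limit: the limit of > 100000 nM in this assay, at which 3 of the 4 values shown sit.

The compounds shown leave open whether exchanging 2-fluorophenyl for pentan-3-yl changes the result in this assay at all.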